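The compounds below may be only part of what the source reports. "The series", "measured", "known", "first", "only" and "open" are said of these compounds alone.

Measured so far:
- compound 1 `COc1ccc(C(=O)OC2(C(=O)Nc3ccc([N+](=O)[O-])cc3)CCCCC2)cc1`: 38.8 nM
- compound 2 `O=C(/C=C/c1ccccc1)OC1(C(=O)Nc2ccc([N+](=O)[O-])cc2)CCCCC1`: 50.5 nM

Both numbers come from a functional assay on NFS-60 cells (Mus musculus) for inhibition, read by MTT assay, with a stated time of 72 h; a lower number here means a stronger inhibitor, a higher number a weaker inhibitor. Within the data shown here, on the two values shown, compound 1 has the lower number, but its only neighbour is compound 2, and the step from it is a 1.3-fold higher number from compound 1 to compound 2 (0.11 log units; within the scatter); the two compounds cannot be ranked.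

Compound 3 `O=C(OC1(C(=O)Nc2ccc([N+](=O)[O-])cc2)CCCCC1)C(O)c1ccccc1` is not yet measured. It differs from compound 1 in one place: hydroxy(phenyl)methyl in place of 4-methoxyphenyl on a carbonyl carbon.

Among the measured compounds shown here, only one measured step bears on this position. The step of a 1.3-fold higher number from compound 1 to compound 2 (0.11 log units; within the scatter) swaps the same aryl ester fragment for a different group and stays within the scatter. The change to compound 3 is of the same kind, an exchange of the group on that carbonyl carbon, so the expectation is a step in this assay of similar small size, the direction open, likely not beyond the scatter. The change from compound 1 to compound 3 is expected to be a 1.4-fold higher number from compound 1 to compound 3 (0.15 log units; within the scatter). Compound 3 is therefore expected to give 55 nM in this assay, with a range from 20 nM to 150 nM.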

Compound 3, half-maximal inhibitory concentration: 7.8 nM
Compound 3: the middle estimate sits 7.1-fold (0.85 log units) above what was measured; the whole stated range lies above it.
By their numbers in this assay, from the lowest: compound 3; then compounds 1 and 2 (each within the scatter of the next).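

Exchanges on this carbonyl carbon are not all equally silent in this assay: a 1.3-fold higher number from compound 1 to compound 2 (0.11 log units; within the scatter), yet a 5.0-fold lower number from compound 1 to compound 3 (0.70 log units; beyond the scatter), and a 6.5-fold lower number from compound 2 to compound 3 (0.81 log units; beyond the scatter). Compound 3 is thus separated beyond the scatter from both earlier compounds, and the position proves able to register a change that the first pair did not reveal. Between compound 1 and compound 3 the atoms are the same and the groups match in heavy atoms, aromatic ring and hydrogen-bond acceptor count, with the hydrogen-bond donor of hydroxy(phenyl)methyl as the counted difference, though no measurement at hand accounts for the step.

From the compounds shown here alone, whether the hydroxy group itself carries the step stays open, and a phenylmethyl or an amino(phenyl)methyl group on the same carbonyl carbon would bear directly on that question. Also open is whether hydroxy(phenyl)methyl gives a step of similar size on any other core, as all three compounds shown share one.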